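Pyridyl substituent changes in an oxazole ketone series

A few compounds are considered here, and "the series" means these few. Any claim that something is new, unique, unknown or untested is made for them only; others in the source may bear on it.

Measured compounds and their numbers in an assay for inhibition of Fatty-acid amide hydrolase 1 (Rattus norvegicus), using a Dixon plot; a higher number here means a weaker inhibitor, a lower number a stronger inhibitor:
Compound 1 `COC(=O)c1ccc(-c2cnc(C(=O)CCCCCCc3ccccc3)o2)nc1` gives 3.1 nM.
Compound 2 `COCOCc1ccc(-c2cnc(C(=O)CCCCCCc3ccccc3)o2)nc1` gives 10.1 nM.
Compound 3 `CSCc1ccc(-c2cnc(C(=O)CCCCCCc3ccccc3)o2)nc1` gives 11.1 nM.

Compound 3 holds the highest number of the three, but its gap to compound 2 is within the scatter, so these two cannot be ordered; only compound 1 sits clearly lower, with a 3.6-fold higher number from compound 1 to compound 3 (0.55 log units; beyond the scatter).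

Compound 4 `CCOS(=O)(=O)/C=C/c1ccc(-c2cnc(C(=O)CCCCCCc3ccccc3)o2)nc1` differs from compound 3 as follows: 2-(ethoxysulfonyl)ethenyl in place of (methylsulfanyl)methyl on an aromatic carbon.

Among the compounds with values here, no measured step involves the entering group. The steps that touch this position, a 3.3-fold higher number from compound 1 to compound 2 (0.51 log units; beyond the scatter) and a 3.6-fold higher number from compound 1 to compound 3 (0.55 log units; beyond the scatter), were modest, and a 1.1-fold higher number from compound 2 to compound 3 (0.04 log units; within the scatter) was within the scatter. A change of similar size is expected, most likely toward a lower number, as compound 1 with its methoxycarbonyl shows in this assay 3.1 nM. Compound 4 is therefore estimated at 6 nM, range 2 nM to 20 nM, an expected step of a 1.9-fold lower number from compound 3 to compound 4 (0.27 log units; within the scatter).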

Compound 4, inhibition constant: 2.1 nM
Compound 4: middle estimate off by 2.9-fold (0.46 log units), on the high side; the measured number falls inside the stated range.
By their numbers in this assay, from the lowest: compounds 4 and 1 (each within the scatter of the next); then compounds 2 and 3 (each within the scatter of the next).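

In this assay, this position accepts 2-(ethoxysulfonyl)ethenyl, and the lower number holds against both (methylsulfanyl)methyl (a 5.3-fold lower number from compound 3 to compound 4 (0.72 log units; beyond the scatter)) and (methoxymethoxy)methyl (a 4.8-fold lower number from compound 2 to compound 4 (0.68 log units; beyond the scatter)), each step beyond the scatter. Against methoxycarbonyl, the step (a 1.5-fold lower number from compound 1 to compound 4 (0.17 log units; within the scatter)) stays within the scatter, so compounds 1 and 4 cannot be ordered, though both groups carry double bonds outside the aromatic ring, unlike those of compounds 2 and 3. No available measurement explains these differences.

Open, as far as these compounds go, is whether the ethenyl link or the ethoxysulfonyl end drives the result, and how a carboxylic acid or a primary amide would compare here.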